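This account rests on a few compounds, and the source may have more. Where it says the series, first, only, none or still open, it means among the compounds named here.

Measured in a functional assay on HOP-62 cells (Homo sapiens) for cytotoxicity, read by sulforhodamine B assay, with a stated time of 48 h, tested at 0.01 uM; on this read-out higher numbers stand for a weaker effect at the one concentration tested and lower numbers for a stronger effect:
Compound 1, `COc1cc(-c2cc(/C=C/C(=O)c3ccc(N)cc3)[nH]n2)cc(OC)c1OC`, gives 83%.
Compound 2, `COc1cc(-c2cc(/C=C/C(=O)c3ccc(Cl)c(Cl)c3)[nH]n2)cc(OC)c1OC`, gives 99%.
Compound 3, `COc1ccc(C(=O)/C=C/c2cc(-c3cc(OC)c(OC)c(OC)c3)n[nH]2)cc1OC`, gives 101%.

On these three numbers compound 3 stands highest in this assay. Its closest company is found in the step of a number 2 percentage points higher from compound 2 to compound 3 (within the scatter), so these two cannot be told apart. The larger gaps both involve compound 1: a number 18 percentage points higher from compound 1 to compound 3 (beyond the scatter), and likewise a number 16 percentage points higher from compound 1 to compound 2 (beyond the scatter). Among the measured compounds shown here, the only two steps beyond the scatter therefore both replace the 4-aminophenyl group on the carbonyl carbon, and both raised the number by a modest amount.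

Compound 4, `COc1cc(C(=O)/C=C/c2cc(-c3cc(OC)c(OC)c(OC)c3)n[nH]2)cc(OC)c1OC`, differs from compound 3 in one place: methoxy in place of hydrogen on an aromatic carbon. For the measured compounds named here, none of the measured steps adds a methoxy group in this way; each swaps the whole aryl group on the carbonyl carbon, and the swap between the two groups each carrying two substituents, a number 2 percentage points higher from compound 2 to compound 3 (within the scatter), stayed within the scatter. With compound 3 already near the top of the range, the step from compound 3 to compound 4 is expected to stay within the scatter, a number 3 percentage points lower from compound 3 to compound 4 (within the scatter). Compound 4 is accordingly estimated at 98%, with a range from 85% to 108%.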

Compound 4, a percentage reported as activity, at one concentration (the size of the read-out at that concentration, not a potency): 97%
The estimate for compound 4 lay 1 percentage points above the measured number; measured number inside the range.
By their numbers in this assay, from the lowest: compound 1; then compounds 4, 2 and 3 (each within the scatter of the next).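

Adding one methoxy group to the aromatic ring on the carbonyl carbon, at a place ortho to a methoxy group and meta to a large group, is the first change here made within an aryl group rather than by swapping the whole group (a number 4 percentage points lower from compound 3 to compound 4 (within the scatter)). The 3,4-dimethoxyphenyl group of compound 3 can therefore take this extra methoxy without the number in this assay moving beyond the usual scatter, although a reading at a single concentration is not a potency and cannot show what happens at other concentrations. Nothing measured here explains this result, so it remains a plain observation.

The compounds shown leave open whether a hydroxy group, a carboxylic acid or a longer ethoxy chain on this same carbon would also keep the number within the scatter. Also open, as far as these compounds go, is whether the same added methoxy would leave the number unchanged on the aminophenyl ring of compound 1 (83%), which has the lowest number of the set.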